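Methoxy for Cyano on a Quinoline Thiosemicarbazone

This account rests on a few compounds, and the source may have more. Where it says the series, first, only, none or still open, it means among the compounds named here.

Measured compounds:
compound 1 `N#Cc1ccc(NC(=S)N/N=C/c2ccc3ccccc3n2)cc1`: 20000 nM
compound 2 `NC(=S)N/N=C/c1nc2ccccc2s1`: 5350 nM

In a functional assay on HeLa cells (Homo sapiens) for antiproliferative activity, read by sulforhodamine B assay, with a stated time of 72 h (a higher number here means a weaker inhibitor, a lower number a stronger inhibitor), compound 1 gives 20000 nM, the highest of the two numbers shown. Going by the values given here, compound 2 gives 5350 nM in this assay, a lower number that lies beyond the scatter, but compound 2 differs from compound 1 in more than one place, so the two values show only that the pair stands apart. Compound 3 `COc1ccc(NC(=S)N/N=C/c2ccc3ccccc3n2)cc1` differs from compound 1 in a single place: methoxy in place of cyano on an aromatic carbon. Among the compounds with values here, no measured pair shows this change, and the data give no steps between compounds differing in one place. A small step is therefore expected in this assay, in either direction, most likely none beyond the scatter. Compound 3 is estimated at 12000 nM, within 4000 nM to 40000 nM. This estimate means an expected step of a 1.7-fold lower number from compound 1 to compound 3 (0.22 log units; within the scatter).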

Compound 3, half-maximal inhibitory concentration: 72600 nM
Compound 3: middle estimate off by 6.1-fold (0.78 log units), on the low side; measured number outside the range, above it.
By their numbers in this assay, from the lowest: compound 2; then compound 1; then compound 3.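

In this assay, going by these compounds alone, the exchange of cyano for methoxy on this aromatic carbon gives the first step between compounds that differ in one place: a 3.6-fold higher number from compound 1 to compound 3 (0.56 log units; beyond the scatter). The earlier compounds shown here could say nothing about this place, and the step now shows that the group held there matters, even though the two groups match in heavy-atom count and hydrogen-bond acceptor count and neither carries a net charge. Nothing in the available data explains why the number rises.

On these data alone, with only these two groups compared at this place, it remains open how far the number can move in either direction. An amine or a carboxylic acid on the same aromatic carbon would test that, and whether the step from cyano to methoxy carries over to another core is also unknown.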